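Pyridin-2-yl alkyne in place of 4-fluorophenyl

The compounds below may be only part of what the source reports. "The series", "measured", "known", "first", "only" and "open" are said of these compounds alone.

The series shares one core, seen in compound 1 `COC(=O)c1sc2cc(C#Cc3ccc(OC)cc3)cnc2c1N`; compound 2 `COC(=O)c1sc2cc(C#Cc3ccc(F)cc3)cnc2c1N` and compound 3 `COC(=O)c1sc2cc(C#Cc3ccccc3N)cnc2c1N` differ from it only in the aryl group on the alkyne. Growth inhibition is read in a functional assay on A375-C5 cells (Homo sapiens) for inhibition, read by sulforhodamine B assay, with a stated time of 48 h; on this read-out higher numbers stand for weaker inhibition of growth and lower numbers for stronger inhibition of growth. Compound 1 reaches only a limit there, > 37500 nM. Compound 2 gives 48400 nM and compound 3 gives 3100 nM. Among the numbers, compound 2 stands highest of the two; the one further value is a limit. The step that the limit leaves unreadable from compound 1 to compound 2 cannot be read. The two readable steps are an at least 12-fold lower number from compound 1 to compound 3 (1.08 log units; beyond the scatter) and a 16-fold lower number from compound 2 to compound 3 (1.19 log units; beyond the scatter), both large and both involving the same 2-aminophenyl group.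

Compound 4 `COC(=O)c1sc2cc(C#Cc3ccccn3)cnc2c1N` is not yet measured. It differs from compound 2 thus: pyridin-2-yl in place of 4-fluorophenyl on a triple-bonded carbon. Going by the values given here, no measured step involves a pyridin-2-yl or any ring carrying a single hydrogen-bond acceptor in place of 4-fluorophenyl, so the large steps to compound 3 do not bear on this change directly; they show only that this position admits changes of aryl group with large effect on the number. Among the compounds with values here, with no closer precedent, the expected step for compound 4 is a 2.4-fold lower number from compound 2 to compound 4 (0.38 log units; beyond the scatter), near the edge of the scatter. Compound 4 is therefore estimated at 20000 nM, between 5000 nM and 60000 nM.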

Compound 4, concentration for 50% growth inhibition: 13900 nM
For compound 4 the middle estimate is 1.4-fold (0.16 log units) above the measured one, within the range that was stated.
By their numbers in this assay, from the lowest: compound 3; then compound 4; then compound 2.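

In this assay, pyridin-2-yl in place of 4-fluorophenyl gives a 3.5-fold lower number from compound 2 to compound 4 (0.54 log units; beyond the scatter), so a ring with a hetero atom and a hydrogen-bond acceptor on the triple-bonded carbon moves the number beyond the scatter, though less than the 2-aminophenyl group does. That group keeps the lowest number of the four compounds, with a 4.5-fold higher number from compound 3 to compound 4 (0.65 log units; beyond the scatter), so pyridin-2-yl covers only part of the large step seen with 2-aminophenyl. Pyridin-2-yl in place of 4-methoxyphenyl gives an at least 2.6-fold lower number from compound 1 to compound 4 (0.43 log units; beyond the scatter), a size that is only a bound, and the step from compound 1 to compound 2 cannot be read, since compound 1 stands at a limit: the limit of > 37500 nM in this assay, at which 1 of the 4 values shown sits.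

What an aminopyridine ring or a hydroxyphenyl ring would give on this triple-bonded carbon stays open, so the compounds shown do not tell whether the number follows the amine of compound 3 or the aromatic ring that carries it. Also open, from the compounds shown here alone, is what a carboxylic acid or an amide would give in place of the methyl ester, which all four compounds share.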